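The compounds below may be only part of what the source reports. "The series", "measured", "known", "first", "only" and "open" are said of these compounds alone.

Within the data shown here, compound 1, `O=C(Nc1nc(-c2ccccc2)nc2c1nnn2Cc1ccccc1)c1ccccc1C(F)(F)F`, is one of two compounds measured in an assay (strain Wistar) for displacement of a labelled ligand from adenosine receptor A1 (Rattus norvegicus), read by scintillation counting (on this read-out higher numbers stand for weaker inhibition and lower numbers for stronger inhibition), and in this assay compound 1 gives 550 nM. That is the higher of the two numbers seen so far. Among the measured compounds shown here, the other compound, compound 2, `O=C(Nc1nc(-c2ccccc2)nc2c1nnn2Cc1ccccc1)c1ccc(C(F)(F)F)cc1`, gives 123 nM in this assay, so that the step of a 4.5-fold lower number from compound 1 to compound 2 (0.65 log units; beyond the scatter) is the only measured comparison available, and it concerns a 4-(trifluoromethyl)phenyl in place of a 2-(trifluoromethyl)phenyl on a carbonyl carbon.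

Compound 3, `O=C(Nc1nc(-c2ccccc2)nc2c1nnn2Cc1ccccc1)C1CC1`, is not yet measured. It differs from compound 1 as follows: cyclopropyl in place of 2-(trifluoromethyl)phenyl on a carbonyl carbon. Here the aromatic group attached to the carbonyl carbon is exchanged for a small non-aromatic ring, a change of a different kind from the one between compound 1 and compound 2. For the measured compounds named here, no measured step speaks directly to this exchange; the only step on record shows that what sits on this carbonyl carbon can move the number by a modest amount. The expectation for compound 3 is therefore uncertain, and the estimate for compound 3 in this assay is 350 nM, within a range from 70 nM to 1800 nM, meaning an expected step of a 1.6-fold lower number from compound 1 to compound 3 (0.20 log units; within the scatter).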

Compound 3, inhibition constant: 7.5 nM
Beside the measured number, compound 3's estimate is 47-fold (1.67 log units) above it, and the stated range ends above it.
By their numbers in this assay, from the lowest: compound 3; then compound 2; then compound 1.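

In this assay, the two earlier compounds both carried a substituted phenyl ring on this carbonyl carbon, so they could show only what a change in the trifluoromethyl placement on that ring does. The new result covers a much bigger exchange, with a group of 10 heavy atoms giving way to cyclopropyl with 3, and it gives a 73-fold lower number from compound 1 to compound 3 (1.87 log units; beyond the scatter) and a 16-fold lower number from compound 2 to compound 3 (1.21 log units; beyond the scatter); both steps are well beyond the earlier 4.5-fold lower number from compound 1 to compound 2 (0.65 log units; beyond the scatter), so in these compounds an aromatic ring on this carbonyl carbon is not needed for a low number. Nothing measured here accounts for why the small ring gives so much lower a number.

Ring size and the loss of aromaticity change together in this exchange, so the compounds shown cannot separate the two. On these data alone, it also remains open how a plain phenyl, a cyclobutyl or cyclopentyl ring, a short chain such as ethyl, or an amine on the same carbonyl carbon would compare with cyclopropyl.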